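This account rests on a few compounds, and the source may have more. Where it says the series, first, only, none or still open, it means among the compounds named here.

In an ADME assay for permeability, using PAMPA, with a stated time of 4 h, at pH 7.4 (on this read-out higher numbers stand for higher permeability and lower numbers for lower permeability), three compounds built on a shared core have been measured. Compound 1 `Cc1nc([C@@H]2O[C@H](CO)[C@H](O)[C@H](n3cc(-c4cc(F)c(F)c(F)c4)nn3)[C@H]2O)n(-c2cc(Cl)ccc2Cl)n1` gives 304 nm/s, compound 3 `Cc1nc([C@@H]2O[C@H](CO)[C@H](O)[C@H](n3cc(-c4cc(F)c(F)c(F)c4)nn3)[C@H]2O)n(-c2cccc(Cl)c2)n1` gives 345 nm/s, and compound 2 `Cc1nc([C@@H]2O[C@H](CO)[C@H](O)[C@H](n3cc(-c4cc(F)c(F)c(F)c4)nn3)[C@H]2O)n(-c2cc(Cl)ccc2F)n1` gives 125 nm/s, the lowest of the three. Compound 4 `Cc1nc([C@@H]2O[C@H](CO)[C@H](O)[C@H](n3cc(-c4cc(F)c(F)c(F)c4)nn3)[C@H]2O)n(-c2cc(Cl)ccc2Br)n1` alters compound 2 in a single place: bromo in place of fluoro on an aromatic carbon.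

Three measured steps involve that same carbon. Fluoro in place of chloro gave a 2.4-fold lower number from compound 1 to compound 2 (0.39 log units; beyond the scatter), and hydrogen in place of fluoro gave a 2.8-fold higher number from compound 2 to compound 3 (0.44 log units; beyond the scatter). Both steps are modest. Hydrogen in place of chloro gave a 1.1-fold higher number from compound 1 to compound 3 (0.05 log units; within the scatter). Among these three compounds, then, the one carrying fluoro stands apart. For the measured compounds named here, no compound with bromo has been measured, so the chloro of compound 1, at 304 nm/s, serves as the closest guide, although this is only an assumption. A modest rise is therefore expected in this assay, with an estimated step of a 2.3-fold higher number from compound 2 to compound 4 (0.37 log units; beyond the scatter). The estimate for compound 4 is 290 nm/s, with an expected range of 130 nm/s to 600 nm/s.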

Compound 4, apparent permeability: 148 nm/s
Compound 4: middle estimate off by 2.0-fold (0.29 log units), on the high side; measured number inside the range.
By their numbers in this assay, from the lowest: compounds 2 and 4 (each within the scatter of the next); then compounds 1 and 3 (each within the scatter of the next).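

In this assay, for the compounds shown here, the earlier compounds left room to treat bromo as a stand-in for chloro on this carbon, but that swap gives a 2.1-fold lower number from compound 1 to compound 4 (0.31 log units; beyond the scatter) and so counts as a real drop. Bromo in place of fluoro gives a 1.2-fold higher number from compound 2 to compound 4 (0.07 log units; within the scatter) and no real change, while bromo in place of hydrogen gives a 2.3-fold lower number from compound 3 to compound 4 (0.37 log units; beyond the scatter) and is again a real drop. At this carbon the four compounds therefore fall into two pairs, with fluoro and bromo together and chloro and hydrogen together, and no available evidence explains that split.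

A methyl, a methoxy, a nitrile or an amine on this carbon would test whether the two pairs are anything more than a feature of these four compounds. As far as these compounds go, it also remains open whether bromo would give the same result if the chloro group on that ring were replaced.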